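The source may hold more compounds than are shown below. What is called first, only, known or untested is meant among the compounds shown, and "the series" means these compounds.

Measured so far:
- compound 1, `CCCCCCCCCCCC/C=C\N(NC(=O)COC)C(=O)OC(C)(C)C`: 28300 nM
- compound 2, `CCCCCCCC/C=C/N(NC(=O)COC)C(=O)OC(C)(C)C`: 45000 nM

In a functional assay on K562 cells (Homo sapiens) for antiproliferative activity, read by resazurin assay, with a stated time of 72 h (on this read-out higher numbers stand for weaker inhibition of growth and lower numbers for stronger inhibition of growth), compound 2 gives 45000 nM. Compound 1, which carries a longer chain and the double bond drawn Z, gives 28300 nM in this assay; the two numbers lie within the scatter of each other, so nothing separates them. For the measured compounds named here, no pair of measured compounds differs in a single place, so no measured step is available for comparison.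

Compound 3, `CCCCCCCC/C=C\N(NC(=O)COC)C(=O)OC(C)(C)C`, is not yet measured. Relative to compound 2: the two compounds have the same atoms and bonds and differ only in configuration as drawn: 1 of 1 stereo elements differ; a double bond is drawn E in compound 2 and Z in compound 3. Going by the values given here, with no measured step for a change in double-bond geometry, and with compound 1 giving 28300 nM as the only Z-drawn reference, the expected step from compound 2 to compound 3 is none beyond the scatter, a 1.3-fold lower number from compound 2 to compound 3 (0.10 log units; within the scatter). For compound 3 the estimated value in this assay is 36000 nM, with a range from 15000 nM to 90000 nM.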

Compound 3, concentration for 50% growth inhibition: 61300 nM
Beside the measured number, compound 3's estimate is 1.7-fold (0.23 log units) below it, within the range that was stated.
By their numbers in this assay, from the lowest: compounds 1, 2 and 3 (each within the scatter of the next, the first and the last beyond it).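

For the compounds shown here, the first clean reading of double-bond geometry is a 1.4-fold higher number from compound 2 to compound 3 (0.13 log units; within the scatter), so E and Z are not separated at this chain length in this assay: the fact that compounds 2 and 3 differ only in the configuration as drawn. With the double bond drawn Z in both compounds, the change of hydrogen in place of butyl on the saturated chain gives a 2.2-fold higher number from compound 1 to compound 3 (0.34 log units; beyond the scatter). This modest step is the only one in the series beyond the scatter, and it places the lower number with the longer chain, so among these three compounds chain length registers while geometry does not.

Going by these compounds, whether geometry would read the same on the longer chain of compound 1 remains open. Also open, on these data alone, is whether a still longer chain, or an amine or a carboxylic acid at the chain end, would move the number further.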